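Fluoro in place of cyano: notes on the series

The source may report more compounds than this note shows. Statements on the series, on what has been measured and on what is new or still open speak of the compounds shown alone.

In an in vitro ADME assay on microsomes from liver (Homo sapiens) for metabolic stability (a lower number here means slower removal, a higher number faster removal of the compound), compound 1 (`CN(C)C(=O)c1cc(Cl)c(NC(=O)N2CCN3C(=O)N([C@H]4C[C@@H]4c4ccccc4)C(=O)[C@@H]3C2)c(Cl)c1`) gives 49000 mL.min-1.g-1, compound 2 (`CS(=O)(=O)c1cc(Cl)c(NC(=O)N2CCN3C(=O)N([C@H]4C[C@@H]4c4ccccc4)C(=O)[C@@H]3C2)c(Cl)c1`) gives 58000 mL.min-1.g-1 and compound 3 (`N#Cc1cc(Cl)c(NC(=O)N2CCN3C(=O)N([C@H]4C[C@@H]4c4ccccc4)C(=O)[C@@H]3C2)c(Cl)c1`) gives 66000 mL.min-1.g-1. Compound 3 therefore stands within the scatter of both others. Compound 4 (`O=C(Nc1c(Cl)cc(F)cc1Cl)N1CCN2C(=O)N([C@H]3C[C@@H]3c3ccccc3)C(=O)[C@@H]2C1`) carries fluoro in place of cyano on an aromatic carbon, para to a large group: fluoro in place of cyano on an aromatic carbon. Three measured exchanges on that aromatic carbon bear on this change: a 1.2-fold higher number from compound 1 to compound 2 (0.07 log units; within the scatter), a 1.3-fold higher number from compound 1 to compound 3 (0.13 log units; within the scatter) and a 1.1-fold higher number from compound 2 to compound 3 (0.06 log units; within the scatter). All three lie within the scatter, although none of them involves fluoro. The estimated 1.0-fold lower number from compound 3 to compound 4 (0.01 log units; within the scatter) is therefore expected to stay within the scatter too. For compound 4 the expected value is 65000 mL.min-1.g-1, with an estimated range from 32000 mL.min-1.g-1 to 130000 mL.min-1.g-1.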

Compound 4, intrinsic clearance in microsomes: 64000 mL.min-1.g-1
The estimate for compound 4 lay 1.0-fold (0.01 log units) above the measured number; measured number inside the range.
By their numbers in this assay, from the lowest: compounds 1, 2, 4 and 3 (each within the scatter of the next).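

In this assay fluoro, with its single heavy atom, gives the steps of a 1.0-fold lower number from compound 3 to compound 4 (0.01 log units; within the scatter) and a 1.1-fold higher number from compound 2 to compound 4 (0.04 log units; within the scatter) and a 1.3-fold higher number from compound 1 to compound 4 (0.12 log units; within the scatter), all within the scatter. This aromatic carbon therefore now carries four groups, including the first halogen there, with no separation among compounds 1 to 4 in this read-out. Nothing shown gives a reason for this. An amine or a carboxylic acid on this carbon could still separate from these four. Going by these compounds, whether fluoro keeps this result without the two chloro groups also stays open.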